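This account rests on a few compounds, and the source may have more. Where it says the series, first, only, none or still open, it means among the compounds named here.

Compound 2 `Cc1ccccc1-n1nc(C)c2c1NC(=O)[C@H](C)S[C@@H]2c1ccc(Oc2ccccc2)cc1` and compound 1 `Cc1ccccc1-n1nc(C)c2c1NC(=O)[C@H](C)S[C@@H]2c1ccc(-c2ccsc2)cc1` share one core. In an assay on isolated protein for agonist activity at Bile acid receptor (Homo sapiens), read by AlphaScreen, with a stated time of 30 min (a lower number here means that less compound is needed, a higher number that more compound is needed for the effect), compound 1 gives 1400 nM, and compound 2 gives 1300 nM, the lowest of the two numbers; the step of a 1.1-fold lower number from compound 1 to compound 2 (0.03 log units; within the scatter) is within the scatter. Compound 3 `Cc1ccccc1-n1nc(C)c2c1NC(=O)[C@H](C)S[C@@H]2c1ccc(Oc2ccc(C(=O)O)cc2)cc1` differs from compound 2 by carboxy in place of hydrogen on an aromatic carbon, on an aromatic carbon of the six-membered ring of carbon only, para to a large group. Among the measured compounds shown here, no measured step concerns a carboxy group, so the direction is uncertain; a moderate step of a 2.2-fold lower number from compound 2 to compound 3 (0.34 log units; beyond the scatter) toward a lower number is expected for compound 3, at 600 nM, estimated between 150 nM and 3000 nM.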

Compound 3, half-maximal effective concentration: "not active" (no number reported)
Nothing numeric was reported for compound 3, so the estimate cannot be set against anything.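

Compound 3 carries no number in this assay, so no step from compound 2 to compound 3 can be read, and nothing measured here accounts for this result. The compounds shown leave open how the 4-carboxyphenoxy group changes the number.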